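Replacing the Benzyl Ether Arm: Compound 2 to Compound 4

The compounds below may be only part of what the source reports. "The series", "measured", "known", "first", "only" and "open" are said of these compounds alone.

compound 1 `FC(F)(F)c1cccnc1N1CCC(NC(=S)Nc2cccnc2)CC1` — > 5000 nM
compound 2 `S=C(Nc1cccnc1)NC1CCN(c2cc(OCc3ccccc3)ccn2)CC1` — 2800 nM
compound 3 `Cc1cnc(N2CCN(NC(=S)Nc3cccnc3)CC2)c(Cl)c1` — > 50000 nM

Among the compounds with values here, in an assay on membranes from brain for binding affinity to Lysophosphatidylserine lipase ABHD12 (Mus musculus), read by fluorescence, with a stated time of 20 min (a higher number here means a weaker inhibitor, a lower number a stronger inhibitor), compound 2 gives 2800 nM, the only number among the three values shown. The value of compound 1 is a limit of the assay, not a number. The value of compound 3 is likewise a limit of the assay. Compound 4 `S=C(Nc1cccnc1)NC1CCN(c2cc(OCC3CC3)ccn2)CC1` differs from compound 2 by cyclopropyl in place of phenyl on a saturated chain carbon bound to an oxygen on an aromatic ring. Within the data shown here, no pair of measured compounds shows a change of this kind, so the size of the step has no precedent here; a small weakening, or no change beyond the usual scatter, seems the most plausible outcome. The estimated step of a 1.8-fold higher number from compound 2 to compound 4 (0.25 log units; within the scatter) reflects that expectation. Compound 4 is expected at 5000 nM, within a range from 1500 nM to 16000 nM.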

Compound 4, half-maximal inhibitory concentration: 4700 nM
Beside the measured number, compound 4's estimate is 1.1-fold (0.03 log units) above it, within the range that was stated.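

In this assay, within the data shown here, the exchange of phenyl for cyclopropyl gives a 1.7-fold higher number from compound 2 to compound 4 (0.22 log units; within the scatter) and is the first one-place change that can be read in this set. On the saturated chain carbon bound to an oxygen on an aromatic ring, a three-membered non-aromatic ring therefore holds the value of a six-membered aromatic ring within the scatter. Nothing measured in the data shown bears on why this is so.

Still open, from the compounds shown here alone, is how an amine, a carboxylic acid or a longer chain would read at this place. Whether any change to this arm can move the value beyond the scatter also remains unsettled.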